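The source may report more compounds than this note shows. Statements on the series, on what has been measured and on what is new or still open speak of the compounds shown alone.

Measured in a functional assay on SF-268 cells (Homo sapiens) for inhibition, read by sulforhodamine B assay, with a stated time of 48 h; a lower number here means a stronger inhibitor of growth, a higher number a weaker inhibitor of growth:
- compound 1 `N#CCC1=NN=C(c2ccc([N+](=O)[O-])cc2)CO1`: 1800 nM
- compound 2 `N#CCC1=NN=C(c2ccc(Br)cc2)C(Br)O1`: 32000 nM

Compound 2 has the higher of the two numbers, and the gap to compound 1 lies beyond the scatter. It is therefore the weaker growth inhibitor of this pair in this assay.

Compound 3 `N#CCC1=NN=C(c2ccc(Br)cc2)CO1` has not yet been measured. It differs from compound 2 at one place, with hydrogen in place of bromo on a saturated ring carbon, next to the ring oxygen: hydrogen in place of bromo on a saturated ring carbon.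

Among the measured compounds shown here, no measured pair of compounds differs in one place only, so the series offers no direct precedent for this change and the expectation rests on two values alone. A step to a lower number, beyond the scatter, is expected, with the result moving toward compound 1 at 1800 nM. The uncertainty remains wide, and a result close to compound 2 cannot be excluded. The expected change is a 5.3-fold lower number from compound 2 to compound 3 (0.73 log units; beyond the scatter). The estimate for compound 3 is 6000 nM, with an expected range from 1500 nM to 25000 nM.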

Compound 3, concentration for 50% growth inhibition: 10300 nM
For compound 3 the middle estimate is 1.7-fold (0.23 log units) below the measured one; the range from low to high includes it.
By their numbers in this assay, from the lowest: compound 1; then compound 3; then compound 2.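

In this assay hydrogen in place of bromo on the saturated ring carbon, next to the ring oxygen, gives a 3.1-fold lower number from compound 2 to compound 3 (0.49 log units; beyond the scatter) and provides the first reading of a single change at this position: among these compounds, the one with bromo there is the weaker growth inhibitor. With hydrogen held at that carbon, bromo in place of nitro on an aromatic carbon gives a 5.7-fold higher number from compound 1 to compound 3 (0.76 log units; beyond the scatter). The gap between compound 1 and compound 2 thus spans changes at two places, each step lying beyond the scatter. No evidence at hand bears on the cause of either step.

From the compounds shown here alone, each change is read on one pair only, so it remains open whether the step seen on removing bromo would carry over to the nitro-bearing core of compound 1. Going by these compounds, nothing here shows how a methyl or hydroxyl group would read on the saturated ring carbon or how an amine or a carboxylic acid would read on the aromatic carbon, and with cyanomethyl constant throughout, a longer chain in its place is also open.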